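This account rests on a few compounds, and the source may have more. Where it says the series, first, only, none or still open, it means among the compounds named here.

Measured compounds in a functional assay on HepG2 cells (Homo sapiens) for antiproliferative activity, read by MTT assay, with a stated time of 72 h; a higher number here means a weaker inhibitor, a lower number a stronger inhibitor:
compound 1, `CC(C)(C)c1ccc(OCCCON2C(N)=NC(N)=NC23CCSCC3)cc1`, 70 nM;
compound 2, `NC1=NC2(CCOCC2)N(OCCCOc2ccccc2Br)C(N)=N1`, 860 nM;
compound 3, `NC1=NC2(CCOCC2)N(OCCCOc2cccc(Br)c2)C(N)=N1`, 320 nM.

Among these three, compound 1 gives the lowest number, with compound 3 nearer to it and compound 2 furthest away. Compound 4, `COc1ccc(OCCCON2C(N)=NC(N)=NC23CCSCC3)cc1`, differs from compound 1 in one place: methoxy in place of tert-butyl on an aromatic carbon. Among the compounds with values here, the only measured step, a 2.7-fold lower number from compound 2 to compound 3 (0.43 log units; beyond the scatter), swaps 3-bromophenyl for 2-bromophenyl on a different core and bears only loosely on an exchange at the position para to a large group. The expectation for compound 4 therefore rests on little; a somewhat higher number than compound 1 is expected, as the step of a 2.1-fold higher number from compound 1 to compound 4 (0.33 log units; beyond the scatter). Compound 4 is thus expected near 150 nM in this assay, within 50 nM to 450 nM.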

Compound 4, half-maximal inhibitory concentration: 880 nM
The estimate for compound 4 lay 5.9-fold (0.77 log units) below the measured number, and the stated range ends below it.
By their numbers in this assay, from the lowest: compound 1; then compound 3; then compounds 2 and 4 (each within the scatter of the next).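

In this assay, methoxy in place of tert-butyl on this aromatic carbon, para to a large group, gives a 13-fold higher number from compound 1 to compound 4 (1.10 log units; beyond the scatter), a large step. The earlier compounds shown here showed only that moving a bromine on another core changes the number; this result shows that, on the core of compound 1, the group held at this position itself matters greatly. Nothing measured here accounts for the size of this step. The compounds shown leave open how an isopropyl or a trifluoromethyl group would fare at this position, and whether the same exchange gives a step of like size on another core.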